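A few compounds are considered here, and "the series" means these few. Any claim that something is new, unique, unknown or untested is made for them only; others in the source may bear on it.

In a functional assay on A549 cells (Homo sapiens) for antiproliferative activity, read by MTT assay (on this read-out lower numbers stand for stronger inhibition and higher numbers for weaker inhibition), compound 1 (`O=C1N=C(N2CCC[C@H]2C(=O)Nc2ccc3ncnc(Nc4cccc(Cl)c4)c3c2)S/C1=C/c1ccc(-c2ccccc2)cc1`) gives 24200 nM. Compound 2 (`O=C1N=C(N2CCC[C@H]2C(=O)Nc2ccc3ncnc(Nc4cccc(Cl)c4)c3c2)S/C1=C/c1cccc(Br)c1`) gives > 50000 nM, which is a limit of the assay and not a number. Compound 2 thus stands at the limit of > 50000 nM in this assay, at which 1 of the 2 values shown sits. Compound 3 (`COc1ccccc1/C=C1/SC(N2CCC[C@H]2C(=O)Nc2ccc3ncnc(Nc4cccc(Cl)c4)c3c2)=NC1=O`) keeps the same core and differs from compound 2 at one place: 2-methoxyphenyl in place of 3-bromophenyl on a double-bonded chain carbon bound to a double-bonded ring carbon. The 2-methoxyphenyl group takes the place of 3-bromophenyl on a double-bonded chain carbon bound to a double-bonded ring carbon. Among the measured compounds shown here, only one measured step bears on this place, an at least 2.0-fold higher number from compound 1 to compound 2 (0.31 log units; beyond the scatter), and it is at least modest. That step does not involve 2-methoxyphenyl, so it gives no direction for the new group. No step beyond the scatter is therefore expected in this assay, and the expected change is an at least 1.1-fold lower number from compound 2 to compound 3 (0.04 log units; that floor lies within the scatter). The estimate for compound 3 is 45000 nM, with an expected range of 18000 nM to 80000 nM.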

Compound 3, half-maximal inhibitory concentration: > 50000 nM
Compound 3: a limit, no number (the forecaster's own chance of this, stated with the estimate: 55%); middle value at least 1.1-fold (0.04 log units) from the limit.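

In this assay compound 3 gives > 50000 nM, which is a limit of the assay and not a number. Compound 2 and compound 3 both stand at limits, so the step between them cannot be read and 2-methoxyphenyl cannot be ordered against 3-bromophenyl on the double-bonded chain carbon; the limit now holds for most of the compounds shown: the limit of > 50000 nM in this assay, at which 2 of the 3 values shown sit. Among the compounds shown here, the one readable result is an at least 2.0-fold higher number from compound 1 to compound 3 (0.31 log units; beyond the scatter), so a second group at this place, after 3-bromophenyl, gives a higher number than 4-phenylphenyl, and compound 1 remains the only one with a measured value.

Going by these compounds, whether a naphthyl group or a pyridyl ring at this place would give a measured value rather than a limit stays open. On these data alone, how far compound 2 and compound 3 lie past the limit also stays open.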